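Dropping the benzyl group: an expectation for compound 4

This account rests on a few compounds, and the source may have more. Where it says the series, first, only, none or still open, it means among the compounds named here.

Measured compounds:
compound 1 `O=c1c(-c2cccc([N+](=O)[O-])c2)nc2ccccc2n1Cc1ccccc1` — in an assay on cells for activation of Cystic fibrosis transmembrane conductance regulator (Homo sapiens), read by fluorescence, with a stated time of 10 min (a lower number here means that less compound is needed, a higher number that more compound is needed for the effect), compound 1 gives 9 nM
compound 2 `O=c1c(-c2ccc(F)c([N+](=O)[O-])c2)nc2ccccc2n1Cc1ccccc1` — in this assay compound 2 gives 690 nM
compound 3 `Cc1cccc2nc(-c3cccc([N+](=O)[O-])c3)c(=O)n(Cc3ccccc3)c12` — in this assay compound 3 gives only a limit, > 10000 nM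

Compound 1 holds the lowest of the two numbers; the nearest is compound 2, with a 77-fold higher number from compound 1 to compound 2 (1.88 log units; beyond the scatter). The step of an at least 1100-fold higher number from compound 1 to compound 3 (3.04 log units; beyond the scatter) is only a bound, since compound 3 sits at the limit of > 10000 nM in this assay, at which 1 of the 3 values shown sits. Compound 4 `O=c1[nH]c2ccccc2nc1-c1cccc([N+](=O)[O-])c1` differs from compound 1 by hydrogen in place of benzyl on an aromatic nitrogen. Both measured steps exchanged a single hydrogen and each cost a great deal. The change to compound 4 removes a whole benzyl group, so a large loss is expected: a 330-fold higher number from compound 1 to compound 4 (2.52 log units; beyond the scatter). Compound 4 is therefore estimated at 3000 nM, expected between 300 nM and 30000 nM.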

Compound 4, half-maximal effective concentration: > 10000 nM
Compound 4 gave a limit, no number; the forecaster's own chance of this, stated with the estimate: 40%; middle value at least 3.3-fold (0.52 log units) away from the limit.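

Compound 2 and compound 3 both kept the benzyl group on the aromatic nitrogen, so they showed nothing about this position. Putting hydrogen there gives an at least 1100-fold higher number from compound 1 to compound 4 (3.04 log units; beyond the scatter) in this assay, so the low number of compound 1 does not survive the loss of benzyl. Compound 4 stands at a limit and not a number, so the full size of this step stays unknown: the limit of > 10000 nM in this assay, at which 2 of the 4 values shown sit.

As far as these compounds go, whether a smaller group on this nitrogen, such as methyl or ethyl, could replace benzyl remains open. So does the effect of a longer chain, or of an amine or a carboxylic acid on the benzyl ring.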